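Notes on the oxamide series: compound 2 toward compound 3

This account rests on a few compounds, and the source may have more. Where it says the series, first, only, none or still open, it means among the compounds named here.

Compound 2 `CCNC(=O)C(=O)CCc1ccc(Cl)cc1` is the weaker of the two measured entries: in an assay on HEK-293T cells for inhibition of phospholipase A and acyltransferase 4 (Homo sapiens), with stated times of 30 min and 20 min (on this read-out lower numbers stand for stronger inhibition and higher numbers for weaker inhibition), compound 2 gives 3980 nM, the highest of the two numbers, while compound 1 `O=C(CCc1ccc(Cl)cc1)C(=O)NCCCCc1ccccc1` gives 1580 nM. Among the compounds with values here, the one measured step is a 2.5-fold higher number from compound 1 to compound 2 (0.40 log units; beyond the scatter), a change on the chain carbon rather than on the amide nitrogen. Compound 3 `CN(C)C(=O)C(=O)CCc1ccc(Cl)cc1` differs from compound 2 by dimethylamino in place of ethylamino on a carbonyl carbon, so that the amide hydrogen of compound 2 is gone. Within the data shown here, no measured step touches this change, and the step from compound 1 to compound 2 gives no guide to it beyond showing that the series tolerates trimming at the amide end only at a modest cost. Without a bearing step, compound 3 is expected to sit close to compound 2, with a small shift toward a higher number, a 1.3-fold higher number from compound 2 to compound 3 (0.10 log units; within the scatter), inside the scatter. Compound 3 is therefore estimated at 5000 nM in this assay, with a range from 1800 nM to 15000 nM.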

Compound 3, half-maximal inhibitory concentration: > 10000 nM
Compound 3: only a limit was reported; the forecaster's own chance of this, stated with the estimate: 10%; at least 2.0-fold (0.30 log units) between middle value and limit.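

Compound 3 in this assay gives > 10000 nM, which is a limit of the assay and not a number. Dimethylamino in place of ethylamino on a carbonyl carbon, the only change shown at this position, is not neutral even though both groups hold the same count of heavy atoms: the result is an at least 2.5-fold higher number from compound 2 to compound 3 (0.40 log units; beyond the scatter). The true size of this step stays open on one side: the limit of > 10000 nM in this assay, at which 1 of the 3 values shown sits.

The counted difference between the two groups is the hydrogen-bond donor of ethylamino, but the compounds shown cannot tell whether its absence alone accounts for the step. Methylamino on the same carbonyl carbon, which keeps the amide hydrogen with a single methyl group, would bear directly on that question.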